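A Chlorinated Methoxyphenyl Sulfonamide Against Porcine Malate Dehydrogenase

A few compounds are considered here, and "the series" means these few. Any claim that something is new, unique, unknown or untested is made for them only; others in the source may bear on it.

Compound 1 `COc1ccccc1S(=O)(=O)Nc1ccc(-c2nc3ccccc3o2)cc1`: in an assay on isolated protein for inhibition of malate dehydrogenase, mitochondrial (Sus scrofa), with stated times of 45 min and 30 min (a lower number here means a stronger inhibitor, a higher number a weaker inhibitor), compound 1 gives > 63000 nM, which is a limit of the assay.
Compound 2 `CCc1ccc(S(=O)(=O)Nc2ccc(-c3nc4ccccc4o3)cc2)cc1`: in this assay compound 2 gives > 63000 nM, again a limit.

Compound 2 thus stands at the limit of > 63000 nM in this assay, at which 2 of the 2 values shown sit, and no number is known for it. The step that the two limits leave unreadable from compound 1 to compound 2 is consequently not readable. Compound 3 `COc1ccc(Cl)cc1S(=O)(=O)Nc1ccc(-c2nc3ccccc3o2)cc1` differs from compound 2 by 5-chloro-2-methoxyphenyl in place of 4-ethylphenyl on a sulfonyl sulfur. Among the compounds with values here, the only measured step bearing on this change is that unreadable one from compound 1 to compound 2, and compound 3 carries a 2-methoxyphenyl as compound 1 does, now as 5-chloro-2-methoxyphenyl. On these numbers no step beyond the scatter can be expected in this assay in either direction, and a further limit is the likely outcome. Compound 3 is therefore estimated at about 80000 nM, with a range of 30000 nM to 300000 nM. The expected step that the limit leaves unreadable from compound 2 to compound 3 lies within the scatter.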

Compound 3, half-maximal inhibitory concentration: > 63000 nM
Compound 3: a limit, no number; the forecaster's own chance of this, stated with the estimate: 85%; the middle value lies beyond the limit too.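

Compound 3 gives > 63000 nM in this assay, which is a limit and not a number. Within the data shown here, no step among compound 1, compound 2 and compound 3 can therefore be read. The compounds shown leave open how strongly each inhibits, as all share one limit: the limit of > 63000 nM in this assay, at which 3 of the 3 values shown sit.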